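Swapping Phenyl for Pyridin-4-yl on a Second Core

The compounds below may be only part of what the source reports. "The series", "measured", "known", "first", "only" and "open" are said of these compounds alone.

Compound 1 `CCNS(=O)(=O)c1ccc(NC2CCCCCCC2)c(NCc2ccccc2)c1` is the reference. In a functional assay (IMR-32 cells, Homo sapiens) for inhibition, read by fluorescence, with stated times of 1 h and 13 h (on this read-out lower numbers stand for stronger inhibition and higher numbers for weaker inhibition), compound 1 gives 2.4 nM. Compound 2 `CCNS(=O)(=O)c1ccc(NC2CCCCCCC2)c(NCc2ccncc2)c1` differs from compound 1 in one place: pyridin-4-yl in place of phenyl on a saturated chain carbon bound to a nitrogen on an aromatic ring. The change produced a 9.2-fold higher number from compound 1 to compound 2 (0.96 log units; beyond the scatter), and compound 2 gives 22 nM in this assay. Compound 3 `CC(C)(C)NS(=O)(=O)c1ccc(NC2CCCCC2)c(NCc2ccccc2)c1` carries a different core; the difference between the core of compound 1 and the core of compound 3 is not broken down here. In this assay compound 3 gives 6.2 nM, a number that sits between the other two, beyond the scatter on both sides. Compound 4 `CC(C)(C)NS(=O)(=O)c1ccc(NC2CCCCC2)c(NCc2ccncc2)c1` has not yet been measured. It differs from compound 3 in one place: pyridin-4-yl in place of phenyl on a saturated chain carbon bound to a nitrogen on an aromatic ring. The place of this change is the same as in the earlier pair, so it is the same change on a second core. The step in this assay is expected to be an 8.9-fold higher number from compound 3 to compound 4 (0.95 log units; beyond the scatter), because the same change already produced a 9.2-fold higher number from compound 1 to compound 2 (0.96 log units; beyond the scatter). Compound 4 is therefore estimated at 55 nM in this assay, with a range from 20 nM to 150 nM.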

Compound 4, half-maximal inhibitory concentration: 11 nM
Estimate against measurement, compound 4: 5.0-fold (0.70 log units) above; measured number outside the range, below it.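

On the second core, pyridin-4-yl in place of phenyl in this assay gives a 1.8-fold higher number from compound 3 to compound 4 (0.25 log units; within the scatter), so here the swap cannot be told apart from the ordinary spread of repeated measurements. Set beside the step on the first core, this shows that the size of the change did not carry over from the core of compound 1 to the core of compound 3: the same change on two cores in this assay, a 9.2-fold higher number (0.96 log units; beyond the scatter) from compound 1 to compound 2 and a 1.8-fold higher number (0.25 log units; within the scatter) from compound 3 to compound 4, 5.2-fold (0.71 log units) apart, beyond the scatter of two such steps. With one pair on each core, and cores that differ in more than one place, the data do not show which difference between the cores goes with the different steps, nor how the swap would behave on any further core.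

From the compounds shown here alone, it remains open whether the swap would give the larger or the smaller step on a core sharing only part of the core of compound 1 and part of the core of compound 3. Also open, going by these compounds, is how other groups in the same place would compare, such as pyridin-3-yl or a phenyl carrying a carboxylic acid.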